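Imine and amide variants on a shared bicyclic core

The compounds below may be only part of what the source reports. "The series", "measured", "known", "first", "only" and "open" are said of these compounds alone.

Compound 3 `CC(=O)CC(=O)NC1=C(C#N)C(c2ccc(Cl)cc2Cl)C2=C(CCCC2=O)N1c1ccc(S(N)(=O)=O)cc1` carries a ((2-oxopropyl)carbonyl)amino group on a double-bonded ring carbon of the shared core. Within the data shown here, in a functional assay on Ehrlich cells (Mus musculus) for cytotoxicity, read by trypan blue exclusion, with a stated time of 2 h, tested at 25 ug/mL (on this read-out lower numbers stand for a weaker effect and higher numbers for a stronger effect at the one concentration tested), compound 3 gives 44%, the highest of the three numbers measured so far. The nearest neighbour is compound 1 `CN(C)c1ccc(/C=N/C2=C(C#N)C(c3ccc(Cl)cc3Cl)C3=C(CCCC3=O)N2c2ccc(S(N)(=O)=O)cc2)cc1`, which in this assay gives 30%; the furthest is compound 2 `CN(C)c1ccc(/C=C/C=N/C2=C(C#N)C(c3ccc(Cl)cc3Cl)C3=C(CCCC3=O)N2c2ccc(S(N)(=O)=O)cc2)cc1`, which in this assay gives 20%. The step of a number 14 percentage points higher from compound 1 to compound 3 (beyond the scatter) is the one that bears on the present change, since it too exchanges the substituent on that double-bonded ring carbon. The step of a number 10 percentage points lower from compound 1 to compound 2 (within the scatter) shows that lengthening the substituent there changed little.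

Compound 4 `CCO/C=N/C1=C(C#N)C(c2ccc(Cl)cc2Cl)C2=C(CCCC2=O)N1c1ccc(S(N)(=O)=O)cc1` is the next variant: a group of 5 heavy atoms (3 carbon, 1 nitrogen, 1 oxygen; no ring) in place of a group of 7 heavy atoms (4 carbon, 1 nitrogen, 2 oxygen; no ring), on a double-bonded ring carbon The entering group has no hydrogen-bond donor, unlike the group it replaces. Among the measured compounds shown here, with only one step of modest size and one within the scatter to go on, the expected change in this assay is small, and the estimated step is a number 8 percentage points lower from compound 3 to compound 4 (within the scatter). Compound 4 is therefore expected to give about 36% in this assay, with a range from 20% to 52%.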

Compound 4, a percentage reported as activity, at one concentration (the size of the read-out at that concentration, not a potency): 30%
Beside the measured number, compound 4's estimate is 6 percentage points above it; measured number inside the range.
By their numbers in this assay, from the lowest: compounds 2, 1 and 4 (each within the scatter of the next); then compound 3.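

In this assay, exchanging the ((2-oxopropyl)carbonyl)amino group on the double-bonded ring carbon gives a number 14 percentage points lower from compound 3 to compound 4 (beyond the scatter), so this higher number does not carry over to a group that lacks the amide hydrogen. On the carbon with a double bond to nitrogen, ethoxy gives no change at the digits printed from compound 1 to compound 4 (within the scatter) and a number 10 percentage points higher from compound 2 to compound 4 (within the scatter), so a number of this size there does not depend on an aromatic ring in that substituent. No measured property accounts for the separation of the amide from the three compounds with that double bond to nitrogen.

An acetylamino group on the same ring carbon would show whether the amide alone or also the ketone carbonyl of the chain goes with the higher number. On these data alone, how a longer alkoxy chain or an amine on the carbon with a double bond to nitrogen would read remains open.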